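Methyl to Chloro on Two Cores: Cytotoxicity Step

The source may hold more compounds than are shown below. What is called first, only, known or untested is meant among the compounds shown, and "the series" means these compounds.

Measured compounds:
compound 1, `CSc1ccc(N(C)c2nc(C)nc3ccccc23)cc1`: 1.1 nM
compound 2, `COc1cccc2cc(N(C)c3nc(C)nc4ccccc34)ccc12`: 1.7 nM
compound 3, `CSc1ccc(N(C)c2nc(Cl)nc3ccccc23)cc1`: 3.2 nM

All three were tested in a functional assay on HeLa cells (Homo sapiens) for cytotoxicity, read by sulforhodamine B assay; on this read-out higher numbers stand for weaker inhibition and lower numbers for stronger inhibition. Compound 3 differs from compound 1 by chloro in place of methyl on an aromatic carbon; this gave a 2.9-fold higher number from compound 1 to compound 3 (0.46 log units; beyond the scatter). Compound 2 and compound 1 give numbers within the scatter of each other, and the difference between the two cores is not broken down here.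

Compound 4 `COc1cccc2cc(N(C)c3nc(Cl)nc4ccccc34)ccc12` has not yet been measured. Going by the values given here, it differs from compound 2 by chloro in place of methyl on an aromatic carbon, which is the same change, at a place described in the same words, as the one from compound 1 to compound 3. In this assay the step from compound 2 to compound 4 is therefore expected to be a 2.9-fold higher number from compound 2 to compound 4 (0.46 log units; beyond the scatter), because a 2.9-fold higher number from compound 1 to compound 3 (0.46 log units; beyond the scatter) was seen for the same change. Compound 4 is estimated at 4.9 nM, most likely between 2 nM and 12 nM.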

Compound 4, half-maximal inhibitory concentration: 1.6 nM
The estimate for compound 4 lay 3.1-fold (0.49 log units) above the measured number; the measured number lies below the stated range.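

In this assay, chloro in place of methyl on an aromatic carbon gave a 1.1-fold lower number from compound 2 to compound 4 (0.03 log units; within the scatter) and so left the number on this core within the scatter. The step seen on the core of compound 1 therefore did not carry over to the core of compound 2: the same change on two cores in this assay, a 2.9-fold higher number (0.46 log units; beyond the scatter) from compound 1 to compound 3 and a 1.1-fold lower number (0.03 log units; within the scatter) from compound 2 to compound 4, 3.1-fold (0.49 log units) apart, beyond the scatter of two such steps. Going by these compounds alone, this shows that, in this series, the size of this change's step depends on the core, but with only two pairs it does not show what in the cores sets the difference, or which step a further core would follow.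

The compounds shown leave open how an amine or a nitrile in place of methyl, on the aromatic carbon between two ring nitrogen atoms, would behave on these two cores. They also leave open whether the two cores would part in the same way with those groups.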